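A few compounds are considered here, and "the series" means these few. Any claim that something is new, unique, unknown or untested is made for them only; others in the source may bear on it.

Measured so far:
- Compound 1, `Cc1noc(NS(=O)(=O)c2ccc(N/C(S)=N\c3ccnc4cc(C(F)(F)F)ccc34)cc2)c1C`: "not active" (no number reported)
- Compound 2, `O=S(=O)(Nc1ccccn1)c1ccc(N/C(S)=N\c2ccnc3cc(C(F)(F)F)ccc23)cc1`: 68800 nM
- Compound 3, `O=S(=O)(Nc1ncccn1)c1ccc(N/C(S)=N\c2ccnc3cc(C(F)(F)F)ccc23)cc1`: "not active" (no number reported)

These three compounds share one core and differ only in the ring attached to the sulfonamide nitrogen. In a functional assay on HeLa cells (Homo sapiens) for antiproliferative activity, read by sulforhodamine B assay, with a stated time of 48 h (on this read-out higher numbers stand for weaker inhibition and lower numbers for stronger inhibition), compound 2 gives 68800 nM. Compound 3 is recorded in this assay as "not active" (no number reported), with no number given, and compound 1 stands the same way, so two of the three entries carry no value at all, and compound 3 stands at the inactive end of what has been seen.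

Compound 4, `Cc1ccnc(NS(=O)(=O)c2ccc(N/C(S)=N\c3ccnc4cc(C(F)(F)F)ccc34)cc2)n1`, is the next compound to be tested. It differs from compound 3 in one place: methyl in place of hydrogen on an aromatic carbon. Within the data shown here, no pair of measured compounds shows what such a small addition does here, so the size of the step in this assay cannot be read from the data. Given that compound 3 itself was recorded as "not active" (no number reported), nothing suggests a change beyond the scatter, and the most likely outcome is that compound 4 again shows no measurable activity or only very weak inhibition. Compound 4 is therefore estimated at 100000 nM, within a range from 30000 nM to 300000 nM.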

Compound 4, half-maximal inhibitory concentration: 31000 nM
Beside the measured number, compound 4's estimate is 3.2-fold (0.51 log units) above it; the range from low to high includes it.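

Adding a methyl to the pyrimidin-2-yl ring, on the aromatic carbon next to the ring nitrogen, goes with a change from an entry without a number to a measurable one: in this assay compound 4 gives 31000 nM, whereas compound 3 gives "not active" (no number reported) and so allows no step of any size to be read, as is also true of compound 1. The set now has its first step with a size, a 2.2-fold lower number from compound 2 to compound 4 (0.35 log units; beyond the scatter), which shows that exchanging these two rings on the sulfonamide nitrogen gives a modest gain in inhibition, although the two compounds differ by more than the methyl alone. Nothing measured here accounts for either observation.

Still open, on these data alone, is whether this aromatic carbon tolerates more than a methyl, for instance an ethyl, a methoxy or an amine, and whether any of these would lower the number further. Also open, as far as these compounds go, is whether the same methyl would have a similar effect on the pyridin-2-yl ring of compound 2.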